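The source may hold more compounds than are shown below. What is called first, only, known or untested is meant among the compounds shown, and "the series" means these compounds.

In a functional assay on A549 cells (Homo sapiens) for inhibition, read by MTT assay, with a stated time of 48 h (a lower number here means a stronger inhibitor, a higher number a weaker inhibitor), the three measured compounds stand as follows:

compound 1 `CCn1c(/C=C2\SC(=O)N(CC(=O)Nc3cc(C(C)(C)C)on3)C2=O)nc2ccccc21` gives 44800 nM.
compound 2 `CCn1c(/C=C2\SC(=O)N(CC(=O)N3CC(C)OC(C)C3)C2=O)nc2ccccc21` reaches only a limit of the assay, > 50000 nM.
compound 3 `CC1CN(C(=O)CN2C(=O)S/C(=C\c3nc4ccccc4n3C(C)C)C2=O)CC(C)O1` likewise reaches only a limit of the assay, > 50000 nM.

All three share one core. Compound 1 and compound 2 differ at the carbonyl carbon: (5-(tert-butyl)-1,2-oxazol-3-yl)amino in place of 2,6-dimethylmorpholin-4-yl on a carbonyl carbon. The step this makes is an at least 1.1-fold lower number from compound 2 to compound 1 (0.04 log units; that floor lies within the scatter), so the two values cannot be told apart. Compound 2 and compound 3 differ in the core itself: methyl in place of hydrogen on a saturated chain carbon bound to an aromatic nitrogen and a saturated chain carbon, and the step is a step that the two limits leave unreadable from compound 2 to compound 3. Of compound 3 it can be said only that it sits at the same limit as compound 2 (the limit of > 50000 nM in this assay, at which 2 of the 3 values shown sit).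

Compound 4 `CC(C)n1c(/C=C2\SC(=O)N(CC(=O)Nc3cc(C(C)(C)C)on3)C2=O)nc2ccccc21` has not yet been measured in this assay. Going by the values given here, it differs from compound 3 by (5-(tert-butyl)-1,2-oxazol-3-yl)amino in place of 2,6-dimethylmorpholin-4-yl on a carbonyl carbon; the place is worded the same for both pairs, so this is the same change as the one from compound 2 to compound 1. The step from compound 3 to compound 4 is expected to be small, estimated at an at least 1.0-fold lower number from compound 3 to compound 4 (0.02 log units; that floor lies within the scatter), because the same change already gave only an at least 1.1-fold lower number from compound 2 to compound 1 (0.04 log units; that floor lies within the scatter) with a floor inside the scatter. Compound 4 is therefore expected to land near 47000 nM, with a span from 22000 nM to 100000 nM, and a fair chance that this assay reports no number for compound 4 but only a limit.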

Compound 4, half-maximal inhibitory concentration: > 50000 nM
Compound 4: only a limit was reported (the forecaster's own chance of this, stated with the estimate: 55%); at least 1.0-fold (0.02 log units) between middle value and limit.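

In this assay compound 4 reaches only a limit of the assay, > 50000 nM, and it joins most of the compounds shown there: the limit of > 50000 nM in this assay, at which 3 of the 4 values shown sit.

Going by these compounds alone, compound 3 also stands at a limit, so the step made on its core by (5-(tert-butyl)-1,2-oxazol-3-yl)amino in place of 2,6-dimethylmorpholin-4-yl cannot be read, and neither can any other step between two limits; the result therefore neither shows that the change carries over from the core of compound 2 to the core of compound 3 nor shows that it fails to carry, and it shows only that the change gave no measured number on the second core. Within the data shown here, the one readable new step, an at least 1.1-fold higher number from compound 1 to compound 4 (0.04 log units; that floor lies within the scatter), belongs to methyl in place of hydrogen on a saturated chain carbon bound to an aromatic nitrogen and a saturated chain carbon, and it gives no firm sign that this change matters.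

Compound 1 alone gives a number, 44800 nM, so the compounds shown offer no measured range within which the two changes could be compared. Open too, going by these compounds, is how a carboxylic acid, a primary amine or a longer chain on the carbonyl carbon would read in this assay, and whether any of them would give a number on either core.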